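Swapping Vinyl for Piperidin-4-yl: Expected Cytotoxicity

A few compounds are considered here, and "the series" means these few. Any claim that something is new, unique, unknown or untested is made for them only; others in the source may bear on it.

Three compounds sharing one core were tested in a functional assay on LNCaP cells (Homo sapiens) for cytotoxicity, read by MTT assay, with a stated time of 48 h; on this read-out higher numbers stand for weaker inhibition and lower numbers for stronger inhibition. Compound 1 `c1ccc2c(-c3coc(-c4ccncc4)n3)c[nH]c2c1` gives 238000 nM. Compound 2 `c1ccc2c(-c3cocn3)c[nH]c2c1` gives 382000 nM. Compound 3 `C=Cc1nc(-c2c[nH]c3ccccc23)co1` gives 530000 nM, the highest of the three numbers; its gap to compound 2 lies within the scatter, while a 2.2-fold higher number from compound 1 to compound 3 (0.35 log units; beyond the scatter) is a modest step beyond it.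

Compound 4 `c1ccc2c(-c3coc(C4CCNCC4)n3)c[nH]c2c1` has not yet been measured. It differs from compound 3 by piperidin-4-yl in place of vinyl on an aromatic carbon. Within the data shown here, two measured steps bear on this change. a 1.4-fold higher number from compound 2 to compound 3 (0.14 log units; within the scatter) shows that placing vinyl where hydrogen sat changed little. a 2.2-fold higher number from compound 1 to compound 3 (0.35 log units; beyond the scatter) shows that replacing a six-membered aromatic ring with vinyl on that aromatic carbon gave a modestly higher number. Piperidin-4-yl brings back a six-membered ring with one nitrogen, though saturated and carrying a hydrogen-bond donor rather than aromatic, so the nearest guide is the step between compound 1 and compound 3 run in reverse. A small lowering of the number is therefore expected, a 1.8-fold lower number from compound 3 to compound 4 (0.25 log units; within the scatter), possibly still within the scatter. Compound 4 is expected to give about 300000 nM in this assay, with a range from 130000 nM to 700000 nM.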

Compound 4, half-maximal inhibitory concentration: 476000 nM
The estimate for compound 4 lay 1.6-fold (0.20 log units) below the measured number, within the range that was stated.
By their numbers in this assay, from the lowest: compounds 1, 2, 4 and 3 (each within the scatter of the next, the first and the last beyond it).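

In this assay, among these compounds, the position is an aromatic carbon of the five-membered aromatic ring, next to the ring nitrogen and next to the ring oxygen, and it now carries a saturated ring with a hydrogen-bond donor for the first time. Even so, piperidin-4-yl does not separate from the small groups it was compared with: replacing vinyl gives a 1.1-fold lower number from compound 3 to compound 4 (0.05 log units; within the scatter), and replacing hydrogen gives a 1.2-fold higher number from compound 2 to compound 4 (0.10 log units; within the scatter). Set against the aromatic ring of compound 1, the result is a 2.0-fold higher number from compound 1 to compound 4 (0.30 log units; within the scatter), so the saturated ring cannot be told apart from pyridin-4-yl either, and no measurement here offers an explanation for any of these results.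

What the compounds shown leave open is whether any group at this position can move the number well beyond the scatter, for example a carboxylic acid, a longer chain ending in a primary amine, or a phenyl ring. Going by these compounds, it also remains open whether the hydrogen on the piperidine nitrogen matters, a question that 1-methylpiperidin-4-yl at the same position could address.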